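Swapping a Bromophenyl for a Dimethoxyphenyl: Cytotoxicity Outlook

The source may hold more compounds than are shown below. What is called first, only, known or untested is meant among the compounds shown, and "the series" means these compounds.

Compound 3 `O=C(NCc1cccc(Br)c1)c1c([N+](=O)[O-])noc1-c1ccc(Cl)cc1Cl` shares its core with compound 1 `O=C(NCc1ccccc1)c1c([N+](=O)[O-])noc1-c1ccc(Cl)cc1Cl` and compound 2 `O=C(NCc1ccc(F)cc1)c1c([N+](=O)[O-])noc1-c1ccc(Cl)cc1Cl`. In an ADME assay on J774.A1 cells (Mus musculus) for cytotoxicity, read by MTT assay, with a stated time of 48 h (a higher number here means that more compound is tolerated, a lower number that less compound is tolerated), compound 2 gives 86400 nM and compound 3 gives 71200 nM; the step of a 1.2-fold lower number from compound 2 to compound 3 (0.08 log units; within the scatter) lies within the scatter, so the two cannot be told apart. In this assay compound 1 gives "not determined" (no result reported). Compound 3 thus sits at the smaller of the two numbers shown, but only within the scatter of compound 2. Compound 4 `COc1ccc(CNC(=O)c2c([N+](=O)[O-])noc2-c2ccc(Cl)cc2Cl)cc1OC` differs from compound 3 by 3,4-dimethoxyphenyl in place of 3-bromophenyl on a saturated chain carbon bound to an amide-type nitrogen. Among the measured compounds shown here, only the single measured step bears on this change, and it was small, so no movement beyond the scatter is expected in this assay; the step of a 1.1-fold higher number from compound 3 to compound 4 (0.02 log units; within the scatter) is expected to stay flat. For compound 4 the estimated value is 75000 nM, ranging from 40000 nM to 140000 nM.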

Compound 4, half-maximal cytotoxic concentration: 81800 nM
For compound 4 the middle estimate is 1.1-fold (0.04 log units) below the measured one; low and high end bracket the measured number.
By their numbers in this assay, from the lowest: compounds 3, 4 and 2 (each within the scatter of the next).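

Putting 3,4-dimethoxyphenyl on the saturated chain carbon bound to an amide-type nitrogen gives, in this assay, a 1.1-fold higher number from compound 3 to compound 4 (0.06 log units; within the scatter) and a 1.1-fold lower number from compound 2 to compound 4 (0.02 log units; within the scatter). This place therefore accepts a group of 10 heavy atoms with 2 hydrogen-bond acceptors, in place of either halogen-bearing ring, without a change beyond the scatter. No supporting data explain this flat result.

Going by these compounds, whether the tolerance holds for groups of another kind stays open, such as an amine, a carboxylic acid or a longer chain. Compound 1 has no number, so the plain phenyl cannot serve as a reference.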